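Dinitrophenyl for chlorophenyl on a spiro core at the limit

A few compounds are considered here, and "the series" means these few. Any claim that something is new, unique, unknown or untested is made for them only; others in the source may bear on it.

Compound 1 `Cc1ccc(-n2nncc2CN2C(=O)C3(C(C#N)=C(N)Oc4c3c3nc5ccccc5nc3c3ccccc43)c3ccccc32)c(C)c1`: in a functional assay on HCT-116 cells (Homo sapiens) for antiproliferative activity, read by MTT assay, with a stated time of 48 h (on this read-out lower numbers stand for stronger inhibition and higher numbers for weaker inhibition), compound 1 gives only a limit, > 50000 nM.
Compound 2 `N#CC1=C(N)Oc2c(c3nc4ccccc4nc3c3ccccc23)C12C(=O)N(Cc1cnnn1-c1ccc(Cl)c(Cl)c1)c1ccccc12`: in this assay compound 2 gives only a limit, > 50000 nM.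
Compound 3 `N#CC1=C(N)Oc2c(N)cc3nc4ccccc4nc3c2C12C(=O)N(Cc1cnnn1-c1ccc(Cl)cc1)c1ccccc12`: in this assay compound 3 gives only a limit, > 50000 nM.

Compound 3 thus stands where every measured compound stands, at the limit (the limit of > 50000 nM in this assay, at which 3 of the 3 values shown sit). Compound 4 `N#CC1=C(N)Oc2c(N)cc3nc4ccccc4nc3c2C12C(=O)N(Cc1cnnn1-c1ccc([N+](=O)[O-])cc1[N+](=O)[O-])c1ccccc12` differs from compound 3 in one place: 2,4-dinitrophenyl in place of 4-chlorophenyl on an aromatic nitrogen. Going by the values given here, the single measured step, a step that the two limits leave unreadable from compound 1 to compound 2, has both ends at the limit and is unreadable; it concerns a different swap on an aromatic nitrogen and gives no direction here. Among the compounds with values here, no measured step bears on the change to compound 4, so no step beyond the scatter is expected in this assay. Compound 4 is expected at 50000 nM, with a range from 20000 nM to 150000 nM. The expected step of a number no higher from compound 3 to compound 4 (the limit leaves the size open) is estimated as none beyond the scatter.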

Compound 4, half-maximal inhibitory concentration: 23900 nM
The estimate for compound 4 lay 2.1-fold (0.32 log units) above the measured number, within the range that was stated.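

In this assay, going by these compounds alone, 2,4-dinitrophenyl in place of 4-chlorophenyl on the aromatic nitrogen gives an at least 2.0-fold lower number from compound 3 to compound 4 (0.32 log units; beyond the scatter), the first step that can be read. Compound 3 gives only a limit, > 50000 nM, and the earlier step between compounds at the limit cannot be read. The group on this nitrogen can therefore move the read-out, and compound 4 alone has a value off the limit: the limit of > 50000 nM in this assay, at which 3 of the 4 values shown sit.

On these data alone, whether a single nitro group would do as much as two stays open. So does what an amine or a carboxylic acid on this phenyl ring would give.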